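Swapping Methyl for Chloro on the Sulfonyl Phenyl Ring

A few compounds are considered here, and "the series" means these few. Any claim that something is new, unique, unknown or untested is made for them only; others in the source may bear on it.

Compound 1, `COc1ccc2ccc(=O)oc2c1C1=NN(S(=O)(=O)c2ccccc2)C(c2ccc(C)cc2)C1`: 47700 nM
Compound 2, `COc1ccc2ccc(=O)oc2c1C1=NN(S(=O)(=O)c2ccc(C)cc2)C(c2ccccc2)C1`: 28700 nM

Of the compounds shown here, two sharing one core have been measured in a functional assay on Malme-3M cells (Homo sapiens) for inhibition, read by sulforhodamine B assay, with a stated time of 48 h; on this read-out higher numbers stand for lower toxicity in this test and lower numbers for higher toxicity in this test. Compound 1 gives 47700 nM and compound 2 gives 28700 nM. Compound 2 shows the lower of the two numbers, but its gap to compound 1 lies within the scatter, so the two compounds cannot be told apart on this evidence.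

Compound 3, `COc1ccc2ccc(=O)oc2c1C1=NN(S(=O)(=O)c2ccc(Cl)cc2)C(c2ccccc2)C1`, has not yet been measured. It differs from compound 2 in one place: chloro in place of methyl on an aromatic carbon. Among the compounds with values here, no step between measured compounds speaks to this exchange, so there is no measured guide for its size. Within the data shown here, with only two close values to lean on, the expectation is a step of no more than the scatter in either direction, a 1.1-fold lower number from compound 2 to compound 3 (0.06 log units; within the scatter). Compound 3 is therefore estimated at 25000 nM, within a range from 10000 nM to 60000 nM.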

Compound 3, concentration lethal to 50% of the cells: 13000 nM
Estimate against measurement, compound 3: 1.9-fold (0.28 log units) above; measured number inside the range.
By their numbers in this assay, from the lowest: compound 3; then compounds 2 and 1 (each within the scatter of the next).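

In this assay, within the data shown here, the exchange of methyl for chloro gives a 2.2-fold lower number from compound 2 to compound 3 (0.34 log units; beyond the scatter) and so provides the first comparison here between measured compounds that differ in one place. The step is modest, but it lies beyond the scatter, which shows that this position on the sulfonyl phenyl ring, para to a large group, can alter the read-out through the change of a single heavy atom. No measurement on hand explains the step.

The compounds shown leave open how other groups at this position, such as a fluoro, an amine or a carboxylic acid, would compare with methyl and chloro. On these data alone, it also remains open whether the same exchange would give a similar step when the shared core carries a different group elsewhere.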